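This account rests on a few compounds, and the source may have more. Where it says the series, first, only, none or still open, it means among the compounds named here.

Measured in a functional assay on HCT-116 cells (Homo sapiens) for antiproliferative activity, read by radiometric assay, with a stated time of 72 h; on this read-out lower numbers stand for stronger inhibition and higher numbers for weaker inhibition:

Compound 1 `O=C(CCCCCCC(=O)Nc1cc2ncnc(Nc3ccc(Cl)cc3F)c2s1)NO`: 1790 nM
Compound 2 `COc1ccc(Nc2ncnc3cc(NC(=O)CCCCCCC(=O)NO)sc23)c(C)c1`: 2480 nM

Compound 2 stands within the scatter of compound 1, so these two values set no order between them. Compound 3 `CCc1cccc(Nc2ncnc3cc(NC(=O)CCCCCCC(=O)NO)sc23)c1`, not yet measured, carries 3-ethylphenyl in place of 4-methoxy-2-methylphenyl on a nitrogen on an aromatic ring. Within the data shown here, one measured step bears on this change, since it was made at the same place: a 1.4-fold higher number from compound 1 to compound 2 (0.14 log units; within the scatter). That exchange of one phenyl group for another stayed within the scatter. Among the measured compounds shown here, with this single step as the only guide, no step beyond the scatter is expected in this assay, and no direction can be argued. The expected step is a 1.2-fold lower number from compound 2 to compound 3 (0.07 log units; within the scatter). Compound 3 is estimated at 2100 nM. The expected range for this value runs from 800 nM to 5500 nM.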

Compound 3, half-maximal inhibitory concentration: 1440 nM
The estimate for compound 3 lay 1.5-fold (0.16 log units) above the measured number; the measured number falls inside the stated range.
By their numbers in this assay, from the lowest: compounds 3, 1 and 2 (each within the scatter of the next).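

In this assay, a third phenyl group on this nitrogen gives a 1.7-fold lower number from compound 2 to compound 3 (0.24 log units; within the scatter), and the comparison with the 4-chloro-2-fluorophenyl compound gives a 1.2-fold lower number from compound 1 to compound 3 (0.09 log units; within the scatter). The three phenyl groups therefore set no order at this position, and 3-ethylphenyl, with no hydrogen-bond acceptor, stays within the scatter of 4-methoxy-2-methylphenyl, which has one. Nothing measured here offers a reason for this result.

Going by these compounds, all three compounds keep a phenyl group on this nitrogen, so it remains open whether a cyclohexyl group, a pyridine ring or a phenyl group bearing a carboxylic acid would stay within the same range. The chain on the other side of the core is also the same in all three, which leaves open what a shorter or longer chain would do.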